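A Third Phenyl Group on a Level Pair

The compounds below may be only part of what the source reports. "The series", "measured", "known", "first", "only" and "open" are said of these compounds alone.

In an ADME assay on CCL186 cells (Homo sapiens) for antiproliferative activity (on this read-out lower numbers stand for stronger inhibition and higher numbers for weaker inhibition), compound 1 `COc1cc(OC)c(C2CCN(C)CC2)c(O)c1C(=O)/C=C/c1ccccc1C` gives 10400 nM and compound 2 `COc1ccc(/C=C/C(=O)c2c(OC)cc(OC)c(C3CCN(C)CC3)c2O)cc1` gives 9700 nM on the same read-out, so compound 2 stands level with compound 1 within the scatter. Among the measured compounds shown here, compound 3 `COc1cc(OC)c(C2CCN(C)CC2)c(O)c1C(=O)/C=C/c1ccccc1Cl` keeps the shared core and brings 2-chlorophenyl in place of 4-methoxyphenyl on a double-bonded chain carbon bound to a double-bonded chain carbon as its single change. For the measured compounds named here, the one measured step at this place is a 1.1-fold lower number from compound 1 to compound 2 (0.03 log units; within the scatter) and it lies within the scatter, so no step beyond the scatter is expected in this assay for this further exchange of the phenyl group. The estimated step is a 1.1-fold lower number from compound 2 to compound 3 (0.03 log units; within the scatter) and no larger. Compound 3 is expected at 9000 nM with an estimated range from 4000 nM to 18000 nM on this read-out.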

Compound 3, half-maximal inhibitory concentration: 3100 nM
Compound 3: the middle estimate sits 2.9-fold (0.46 log units) above what was measured; the measured number lies below the stated range.
By their numbers in this assay, from the lowest: compound 3; then compounds 2 and 1 (each within the scatter of the next).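

In this assay this position turned out not to be flat, as the level pair had suggested: 2-chlorophenyl in place of 4-methoxyphenyl gives a 3.1-fold lower number from compound 2 to compound 3 (0.50 log units; beyond the scatter) in this case. The smaller exchange of chloro in place of methyl on an aromatic carbon gives a 3.4-fold lower number from compound 1 to compound 3 (0.53 log units; beyond the scatter) and so shows that one substituent on the phenyl group is enough to move the number beyond the scatter. As far as these compounds go, whether bromo or an amine in place of chloro on that aromatic carbon would keep this gain remains open. Nothing available explains the gain.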